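The compounds below may be only part of what the source reports. "The series", "measured", "known", "first", "only" and "open" are said of these compounds alone.

Of the compounds shown here, three sharing one core have been measured in a functional assay on HCT-116 cells (Homo sapiens) for antiproliferative activity, read by MTT assay, with a stated time of 48 h; a lower number here means a stronger inhibitor, a higher number a weaker inhibitor. Compound 1 `Cc1ccccc1-n1nncc1CN1C(=O)C2(C(C#N)=C(N)Oc3c(N)cc4nc5ccccc5nc4c32)c2ccccc21` gives only an assay limit, > 50000 nM. Compound 2 `CCc1ccccc1-n1nncc1CN1C(=O)C2(C(C#N)=C(N)Oc3c(N)cc4nc5ccccc5nc4c32)c2ccccc21` gives 10300 nM. Compound 3 `N#CC1=C(N)Oc2c(N)cc3nc4ccccc4nc3c2C12C(=O)N(Cc1cnnn1-c1ccccc1Br)c1ccccc12` gives 12400 nM, a number that lies within the scatter of compound 2. The steps of an at least 4.8-fold lower number from compound 1 to compound 2 (0.68 log units; beyond the scatter) and an at least 4.0-fold lower number from compound 1 to compound 3 (0.60 log units; beyond the scatter) are beyond the scatter, whereas a 1.2-fold higher number from compound 2 to compound 3 (0.08 log units; within the scatter) is not. Compound 4 `COc1ccc(-n2nncc2CN2C(=O)C3(C(C#N)=C(N)Oc4c(N)cc5nc6ccccc6nc5c43)c3ccccc32)cc1` differs from compound 3 by 4-methoxyphenyl in place of 2-bromophenyl on an aromatic nitrogen. Among the compounds with values here, none of the measured steps tests this kind of change, so its size is unknown; the one step that swaps groups on that phenyl ring, bromo for ethyl, stayed within the scatter. Compound 4 is therefore expected to sit near compound 3, with a 1.0-fold lower number from compound 3 to compound 4 (0.01 log units; within the scatter) expected to be no step beyond the scatter. Compound 4 is estimated at 12000 nM, between 4000 nM and 40000 nM.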

Compound 4, half-maximal inhibitory concentration: > 50000 nM
Compound 4 ended at the assay's limit (the forecaster's own chance of this, stated with the estimate: 20%); middle value at least 4.1-fold (0.61 log units) from the limit.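

In this assay, the group on the aromatic nitrogen can cost activity when 4-methoxyphenyl enters: replacing 2-bromophenyl gives an at least 4.0-fold higher number from compound 3 to compound 4 (0.60 log units; beyond the scatter), and replacing 2-ethylphenyl gives an at least 4.8-fold higher number from compound 2 to compound 4 (0.68 log units; beyond the scatter). So 4-methoxyphenyl falls short of two groups that stayed within the scatter of each other. The step between compound 1 and compound 4 cannot be read because both values are limits: the limit of > 50000 nM in this assay, at which 2 of the 4 values shown sit.

This swap changes both the group and its place on the phenyl ring, so the two effects remain unseparated. Going by these compounds, whether 2-methoxyphenyl or 4-bromophenyl would behave like compound 3 or compound 4 stays open.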